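The source may hold more compounds than are shown below. What is called first, only, known or untested is meant among the compounds shown, and "the series" means these compounds.

Working notes on the series. In an ADME assay on microsomes from liver (Homo sapiens) for metabolic stability, with a stated time of 10 min (on this read-out higher numbers stand for a more stable compound and lower numbers for a less stable compound), compound 1 (`COc1ccccc1-n1nc([C@H]2C[C@@H](C)O[C@@H](C)C2)cc1-c1ccc(Cl)cc1`) gives 64% and compound 2 (`COc1ccccc1-n1nc(C2CC(C)(C)OC(C)(C)C2)cc1-c1ccc(Cl)cc1`) gives 97% and stands highest of the two numbers, beyond the scatter. Next is compound 3 (`COCCCc1cc(-c2ccc(Cl)cc2)n(-c2ccccc2OC)n1`), with 3-methoxypropyl in place of 2,2,6,6-tetramethyloxan-4-yl on an aromatic carbon. Among the measured compounds shown here, one measured step bears on this place: a number 33 percentage points higher from compound 1 to compound 2 (beyond the scatter) is large and beyond the scatter, with 2,2,6,6-tetramethyloxan-4-yl in place of 2,6-dimethyloxan-4-yl. For the measured compounds named here, no measured compound carries a group without a ring here, so that step is only a loose guide to size. Compound 2 at 97% leaves little room upward, and compound 1 at 64% shows that a different group at this place can give a much lower number on the shared core. A large step down in this assay is therefore expected, of roughly the measured size. The expected step is a number 37 percentage points lower from compound 2 to compound 3 (beyond the scatter) on this estimate. The estimated value for compound 3 is 60% and is expected to fall between 35% and 82% in repeat measurements.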

Compound 3, percent of the compound remaining: 58%
Compound 3: middle estimate off by 2 percentage points, on the high side, and the stated range covers the measured number.
By their numbers in this assay, from the lowest: compounds 3 and 1 (each within the scatter of the next); then compound 2.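

In this assay the step to 3-methoxypropyl, a group with no ring, gives a number 39 percentage points lower from compound 2 to compound 3 (beyond the scatter) and so removes the high number seen with 2,2,6,6-tetramethyloxan-4-yl at this place on the shared core. Set against the other ring, the same chain gives a number 6 percentage points lower from compound 1 to compound 3 (within the scatter) and cannot be told apart from 2,6-dimethyloxan-4-yl, so having a ring at this place does not by itself separate the compounds; among the three, only compound 2 stands apart, and the ring with four methyl groups goes with the high number while the ring with two does not. Nothing measured here gives a reason for this difference.

On these data alone, it remains open whether tert-butyl, which carries no ring, or plain oxan-4-yl, which carries no methyl groups, would read with compound 2 or with compound 1 and compound 3. Also open, as far as these compounds go, is how a longer chain than 3-methoxypropyl, or one ending in an amine in place of the methoxy group, would read at this place.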